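Changing the amide aryl group of a P2X7 antagonist

A few compounds are considered here, and "the series" means these few. Any claim that something is new, unique, unknown or untested is made for them only; others in the source may bear on it.

Of the compounds shown here, two of one shared core have been measured in an assay on HEK293 cells for antagonist activity at P2X purinoceptor 7 (Homo sapiens), read by fluorescence, with a stated time of 2 h; on this read-out lower numbers stand for stronger inhibition and higher numbers for weaker inhibition. Compound 1 `O=C(c1ccc(Cl)c(C(F)(F)F)c1)N1CCC(n2cncc2-c2ccc(OS(=O)(=O)c3cccs3)cc2)CC1` gives 238 nM in this assay. Among the measured compounds shown here, compound 2 `O=C(c1ccc(Cl)c(C(F)(F)F)c1)N1CCC(n2cncc2-c2ccc(OS(=O)(=O)c3cccc4cnccc34)cc2)CC1` gives 45 nM, and the one step between them, a 5.3-fold lower number from compound 1 to compound 2 (0.72 log units; beyond the scatter), is the only change in the data so far. Compound 2 therefore stands with the lowest number of the two measured, and its nearest neighbour is compound 1.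

Compound 3 `CCN(CC)c1ccc(C(=O)N2CCC(n3cncc3-c3ccc(OS(=O)(=O)c4cccc5cnccc45)cc3)CC2)cc1` keeps everything in compound 2 except one group: 4-(diethylamino)phenyl in place of 4-chloro-3-(trifluoromethyl)phenyl on a carbonyl carbon. For the measured compounds named here, this sulfonyl sulfur step from compound 1 to compound 2 touched the other end of the molecule, so no measured step bears on the carbonyl carbon that is changed here. The data give no guide to the size or the direction of the step in this assay, and any expectation for compound 3 rests on the fact that compound 2 is the starting point.

For compound 3 the expected value in this assay is 200 nM, with a wide range from 40 nM to 1500 nM, an expected step of a 4.4-fold higher number from compound 2 to compound 3 (0.65 log units; beyond the scatter).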

Compound 3, half-maximal inhibitory concentration: 1440 nM
Beside the measured number, compound 3's estimate is 7.2-fold (0.86 log units) below it; low and high end bracket the measured number.
By their numbers in this assay, from the lowest: compound 2; then compound 1; then compound 3.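

The step at the carbonyl carbon, measured in this assay, is a 32-fold higher number from compound 2 to compound 3 (1.51 log units; beyond the scatter), which shows that this position is far from indifferent to the aryl group it carries. Among the compounds shown here, this step is larger than a 5.3-fold lower number from compound 1 to compound 2 (0.72 log units; beyond the scatter), the change made on the sulfonyl sulfur, so in these two single changes the amide aryl group moves the number more, even though each change is only one example. The leaving and entering groups both have 11 heavy atoms and one six-membered aromatic ring of carbon only, so those counts do not separate them, and nothing measured here explains why the number rises.

The chlorine and the trifluoromethyl leave together and the diethylamino enters in the same change, so the compounds shown leave open which of these differences carries the step. A plain phenyl, a phenyl with only chlorine or only trifluoromethyl, or a dimethylamino in place of the diethylamino could help pull these apart, and the thiophen-2-yl sulfonyl partner leaves open whether the step holds with a different group on the sulfonyl sulfur.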